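Branching the methylsulfonyl side chain of compound 3

This account rests on a few compounds, and the source may have more. Where it says the series, first, only, none or still open, it means among the compounds named here.

Compound 1 `CC(C)(c1cc([C@@]23CCOC[C@@H]2C3)nc(-c2cccc(O)c2)n1)S(C)(=O)=O`: 4.8
Compound 2 `Oc1cccc(-c2nccc([C@]34CCOC[C@H]3C4)n2)c1`: 4
Compound 3 `CS(=O)(=O)Cc1cc([C@]23CCOC[C@H]2C3)nc(-c2cccc(O)c2)n1`: 3.7

These three numbers come from a physicochemical assay for lipophilicity; on this read-out lower numbers stand for lower lipophilicity and higher numbers for higher lipophilicity. Compound 3, at 3.7, is level with compound 2 within the usual scatter, and the numbers show it clearly under compound 1, which gives 4.8.

Compound 4 `CC(C)(c1cc([C@]23CCOC[C@H]2C3)nc(-c2cccc(O)c2)n1)S(C)(=O)=O` has not yet been measured. It differs from compound 3 in one place: 1-methyl-1-(methylsulfonyl)ethyl in place of (methylsulfonyl)methyl on an aromatic carbon.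

Among the measured compounds shown here, only one measured step involves this side chain: a number 0.30 log units lower from compound 2 to compound 3 (within the scatter). That step brings in (methylsulfonyl)methyl in place of hydrogen, and it stays within the scatter, so it says little about the larger group.

Compound 1 offers closer evidence. It carries the same 1-methyl-1-(methylsulfonyl)ethyl group and gives 4.8, and its core is the mirror image of the core in compound 4. Two mirror-image forms are expected to read alike in a partition measurement, so a rise beyond the scatter is expected here rather than a flat result.

The expected size of this rise is a number 1.10 log units higher from compound 3 to compound 4 (beyond the scatter).

For compound 4 the estimate is 4.8, with an expected range from 4.5 to 5.1.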

Compound 4, partition coefficient: 4.8
Compound 4: the middle estimate sits on the measured number at the digits printed; the measured number falls inside the stated range.
By their numbers in this assay, from the lowest: compounds 3 and 2 (each within the scatter of the next); then compounds 1 and 4 (each within the scatter of the next).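

In this assay, 1-methyl-1-(methylsulfonyl)ethyl in place of (methylsulfonyl)methyl on this aromatic carbon gives a number 1.10 log units higher from compound 3 to compound 4 (beyond the scatter), so the branched side chain shifts the read-out clearly where the unbranched one stayed within the scatter. Set against plain hydrogen at the same place, the branched group gives a number 0.80 log units higher from compound 2 to compound 4 (beyond the scatter), the first step from hydrogen at this position that lies beyond the scatter. The mirror-image pair adds no change at the digits printed from compound 1 to compound 4 (within the scatter), so in this assay the same side chain reads alike on either mirror-image form of the core, and inverting both stereocentres does not change the number at the digits printed: the fact that compounds 1 and 4 differ only in the configuration as drawn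

The side chains shown at this position all carry the methylsulfonyl group, so it stays open whether a tert-butyl group, made of carbon alone, would give a similar rise. Also open, from the compounds shown here alone, is how the number would respond to an amine, a carboxylic acid or a longer chain on this aromatic carbon.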